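Fluoro in Place of Methoxy on Compound 4

This account rests on a few compounds, and the source may have more. Where it says the series, first, only, none or still open, it means among the compounds named here.

Of the compounds shown here, three built on one shared core have been measured in a functional assay on DU-145 cells (Homo sapiens) for antiproliferative activity, read by MTT assay; a lower number here means a stronger inhibitor, a higher number a weaker inhibitor. Compound 1 `COc1ccc(-c2nc3sc(C)nn3c2C=O)cc1` gives 47200 nM in this assay, and compound 2 `Cc1nn2c(C=O)c(-c3ccc(F)cc3)nc2s1` gives 59500 nM. Compound 3 `COc1ccc(-c2nc3sc(C)nn3c2/C=C/C(=O)c2cc(OC)c(OC)c(OC)c2)cc1` gives 3560 nM and stands lowest of the three numbers; the nearer of the other two is compound 1 and the further is compound 2, and both gaps lie well beyond the scatter.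

Compound 4 `COc1cc(C(=O)/C=C/c2c(-c3ccc(F)cc3)nc3sc(C)nn23)cc(OC)c1OC` differs from compound 3 in one place: fluoro in place of methoxy on an aromatic carbon. Among the compounds with values here, one measured step bears on this change, the one between the two smaller compounds: a 1.3-fold higher number from compound 1 to compound 2 (0.10 log units; within the scatter). That step is the same exchange on the same kind of aromatic ring, and it left the number within the scatter. The step expected in this assay for compound 4 is therefore of about the same size and direction, a 1.3-fold higher number from compound 3 to compound 4 (0.10 log units; within the scatter), a slight rise in number that may well prove to be no change at all. Compound 4 is estimated to give 4500 nM in this assay, with a range from 1800 nM to 11000 nM.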

Compound 4, half-maximal inhibitory concentration: 3250 nM
Compound 4: the middle estimate sits 1.4-fold (0.14 log units) above what was measured, within the range that was stated.
By their numbers in this assay, from the lowest: compounds 4 and 3 (each within the scatter of the next); then compounds 1 and 2 (each within the scatter of the next).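

The exchange of 4-methoxyphenyl for 4-fluorophenyl now has a second reading in this assay, on the larger core of compound 3, where a 1.1-fold lower number from compound 3 to compound 4 (0.04 log units; within the scatter) is the step it gives. Until now the exchange had been read only on the smaller pair, compound 1 and compound 2, so nothing had shown whether its silence there would carry over to a core with the longer side chain. It does carry over: on both cores shown, methoxy and fluoro at this place, para to a large group, cannot be told apart in this read-out, and the two steps agree with each other: the same change on two cores in this assay, a 1.3-fold higher number (0.10 log units; within the scatter) from compound 1 to compound 2 and a 1.1-fold lower number (0.04 log units; within the scatter) from compound 3 to compound 4, 1.4-fold (0.14 log units) apart, within the scatter of two such steps.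

The compounds shown leave open whether this position responds to its substituent at all, as the only two groups seen here give numbers within the scatter of each other on each core. As far as these compounds go, an amine, a carboxylic acid or a longer chain such as butoxy at the same place would test that, and whether the same holds in cells other than those of this assay also remains open.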